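This account rests on a few compounds, and the source may have more. Where it says the series, first, only, none or still open, it means among the compounds named here.

Measured compounds in a functional assay on MCF7 cells (Homo sapiens) for cytotoxicity, read by MTT assay, with a stated time of 48 h; a higher number here means a weaker inhibitor, a lower number a stronger inhibitor:
Compound 1 `COc1ccc(Nc2nc(-c3cccc(F)c3)nc3ccc(F)cc23)cc1` gives 48400 nM.
Compound 2 `Fc1ccc(Nc2nc(-c3cccc(F)c3)nc3ccc(F)cc23)cc1` gives > 50000 nM, a limit of the assay rather than a number.
Compound 3 `Fc1cccc(-c2nc(Nc3cccc(Cl)c3)c3cc(F)ccc3n2)c1` gives > 50000 nM, likewise a limit and not a number.

Compound 3 thus stands at the limit, where two of the three values shown sit (the limit of > 50000 nM in this assay, at which 2 of the 3 values shown sit). The step to compound 4 `Cc1cccc(Nc2nc(-c3cccc(F)c3)nc3ccc(F)cc23)c1` changes (methyl in place of chloro on an aromatic carbon). The measured steps give little to go on: an at least 1.0-fold higher number from compound 1 to compound 2 (0.01 log units; that floor lies within the scatter) and an at least 1.0-fold higher number from compound 1 to compound 3 (0.01 log units; that floor lies within the scatter) are floors that lie within the scatter, and a step that the two limits leave unreadable from compound 2 to compound 3. For the measured compounds named here, no step is readable as a gain. Compound 4 is therefore expected to stay near the limit, with a step that the limit leaves unreadable from compound 3 to compound 4 no larger than the scatter. The estimate for compound 4 is 55000 nM, with a range from 25000 nM to 120000 nM, and a limit is the most likely report.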

Compound 4, half-maximal inhibitory concentration: > 50000 nM
Compound 4: a limit, no number; the forecaster's own chance of this, stated with the estimate: 70%; the middle value lies beyond the limit too.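

In this assay compound 4 gives > 50000 nM as a limit of the assay and not a number. Methyl at this position, like chloro in compound 3, yields no number, and the steps between limits cannot be read. For the compounds shown here, the one readable step is an at least 1.0-fold higher number from compound 1 to compound 4 (0.01 log units; that floor lies within the scatter) and the series gathers at a single ceiling: the limit of > 50000 nM in this assay, at which 3 of the 4 values shown sit.

As far as these compounds go, it remains open whether an amine, a hydroxyl or a carboxylic acid in place of methyl at this position would give a number within the range of the assay.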